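A few compounds are considered here, and "the series" means these few. Any claim that something is new, unique, unknown or untested is made for them only; others in the source may bear on it.

Of the compounds shown here, three built on one shared core have been measured in a functional assay on SW620/5-FU cells (Homo sapiens) for cytotoxicity, read by MTT assay, with a stated time of 48 h, in the presence of a further agent that is not named here; a higher number here means that more compound is needed for the effect, a lower number that less compound is needed. Compound 1 `COc1ccc(-c2cc(NNC(=O)Nc3cc(Cl)nc(Cl)c3)nc3c2cnn3C)cc1`, the chloro member, gives 18500 nM. Compound 2 `COc1ccc(-c2cc(NNC(=O)Nc3cc(Cl)nc(OC(C)C)c3)nc3c2cnn3C)cc1`, which has isopropoxy in place of that chloro, gives 47100 nM. Compound 3 `COc1ccc(-c2cc(NNC(=O)Nc3cc(Cl)nc(OC)c3)nc3c2cnn3C)cc1`, which has methoxy there, gives 48800 nM. Compound 3 therefore stands at the high end of the three numbers, level with compound 2 and clearly separated from compound 1.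

The next compound, compound 4 `CCCCOc1cc(NC(=O)NNc2cc(-c3ccc(OC)cc3)c3cnn(C)c3n2)cc(Cl)n1`, lengthens methoxy to butoxy: propyl in place of hydrogen on a saturated chain carbon bound to an oxygen on an aromatic ring. The closest measured guide is the exchange of methyl and isopropyl on that oxygen, a 1.0-fold higher number from compound 2 to compound 3 (0.02 log units; within the scatter), which lies within the scatter. The replacements of chloro, a 2.5-fold higher number from compound 1 to compound 2 (0.41 log units; beyond the scatter) and a 2.6-fold higher number from compound 1 to compound 3 (0.42 log units; beyond the scatter), were modest, but they concern a different change. Among the compounds with values here, no measured compound carries a butyl chain, so the guide is an incomplete one. No change beyond the scatter is expected, and the expected step is a 1.1-fold lower number from compound 3 to compound 4 (0.04 log units; within the scatter). In this assay the estimated value for compound 4 is 45000 nM, with an expected range of 20000 nM to 100000 nM.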

Compound 4, half-maximal effective concentration: 39200 nM
Beside the measured number, compound 4's estimate is 1.1-fold (0.06 log units) above it; low and high end bracket the measured number.
By their numbers in this assay, from the lowest: compound 1; then compounds 4, 2 and 3 (each within the scatter of the next).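

The butyl chain extends what the earlier pair suggested: in this assay, lengthening methoxy to butoxy gives a step that stays within the scatter (a 1.2-fold lower number from compound 3 to compound 4 (0.10 log units; within the scatter)), and butyl in place of isopropyl on the same oxygen does likewise (a 1.2-fold lower number from compound 2 to compound 4 (0.08 log units; within the scatter)). Methyl, isopropyl and butyl on this oxygen are therefore not told apart here, so among these three chains, length and branching leave no readable mark on the number. Butoxy in place of chloro still falls beyond the scatter, though modestly (a 2.1-fold higher number from compound 1 to compound 4 (0.33 log units; beyond the scatter)), so compound 1 remains separate from all three ether members, and no information is available to explain either the flat response to the chain or this separation.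

The compounds shown leave open whether the flat response continues with a longer chain, such as octyl, or survives a chain ending in an amine or a carboxylic acid. They also leave open whether any group at this position, such as fluoro or bromo, would bring the number below that of the chloro member, compound 1.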